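What a ring swap may do to compound 2

The source may report more compounds than this note shows. Statements on the series, on what has been measured and on what is new or still open speak of the compounds shown alone.

Among the measured compounds shown here, in a physicochemical assay for solubility, measured as kinetic solubility, at pH 2 (a higher number here means a more soluble compound, a lower number a less soluble compound), only two compounds have been measured so far. Compound 1 `CC(C)C(c1ccc(-c2ccc3cccc(F)c3c2)[nH]c1=O)C1NC(=O)NC1=O` gives 5800 nM, and compound 2 `C/C(=C1/OC(=O)NC1=O)C(c1ccc(-c2ccc3cccc(F)c3c2)[nH]c1=O)C(C)C` gives 12700 nM, the higher of the two numbers. Compound 3 `CC(C)C(CC1NC(=O)NC1=O)c1ccc(-c2ccc3cccc(F)c3c2)[nH]c1=O` is still unmeasured. It differs from compound 2 in one place, on a saturated chain carbon bound to an aromatic carbon and a saturated chain carbon: a group of 8 heavy atoms (4 carbon, 2 nitrogen, 2 oxygen; one five-membered non-aromatic ring with 2 hetero atoms) in place of a group of 9 heavy atoms (5 carbon, 1 nitrogen, 3 oxygen; one five-membered non-aromatic ring with 2 hetero atoms), on a saturated chain carbon bound to an aromatic carbon and a saturated chain carbon. The entering group, (2,5-dioxoimidazolidin-4-yl)methyl, holds the same ring that compound 1 carries.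

For the measured compounds named here, only one measured step bears on this change: a 2.2-fold higher number from compound 1 to compound 2 (0.34 log units; beyond the scatter). That step is modest, though beyond the scatter. Since compound 3 returns to the ring of compound 1, a step of similar size in the opposite direction is expected, towards a lower number in this assay. Going by the values given here, this is thin evidence, as no measured compound shows what the methyl part of the entering group does on its own. The expected step is a 2.0-fold lower number from compound 2 to compound 3 (0.29 log units; within the scatter). Compound 3 is therefore estimated at 6500 nM, with an expected range of 2800 nM to 14000 nM.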

Compound 3, solubility: 13000 nM
Estimate against measurement, compound 3: 2.0-fold (0.30 log units) below; low and high end bracket the measured number.
By their numbers in this assay, from the lowest: compound 1; then compounds 2 and 3 (each within the scatter of the next).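

In this assay, replacing one five-membered ring group with the other at this saturated chain carbon gives a 1.0-fold higher number from compound 2 to compound 3 (0.01 log units; within the scatter), so the two groups cannot be told apart here, even though their rings differ. The other comparison is (2,5-dioxoimidazolidin-4-yl)methyl in place of 2,5-dioxoimidazolidin-4-yl, which gives a 2.2-fold higher number from compound 1 to compound 3 (0.35 log units; beyond the scatter); the ring of compound 1 therefore does not go with the lower number wherever it appears, since compound 3 carries that same ring and still stands clear of compound 1. Nothing measured here accounts for either step, so the numbers record what happened without explaining it.

The compounds shown leave open whether a longer chain between this carbon and the ring, such as a two-carbon link, would stay level with compound 3 or move away from it. They also leave open how a group of another kind at this position, such as a carboxylic acid or an amine, would compare with the ring-bearing groups seen so far.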